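The source may report more compounds than this note shows. Statements on the series, on what has been measured and on what is new or still open speak of the compounds shown alone.

Measured in a functional assay (strain AB) with Danio rerio as the target, read by microscopy, with a stated time of 1 h; on this read-out lower numbers stand for an effect already at smaller amounts and higher numbers for an effect only at larger amounts of compound:
compound 1 `NC(=O)c1c(NC(=O)Nc2ccc(Cl)cc2)sc2c1CCN(C1CCOCC1)C2`: 2830 nM
compound 2 `CC(C)(C)OC(=O)N1CCc2c(sc(NC(=O)Nc3ccc(Cl)cc3)c2C(N)=O)C1`: > 25000 nM

Compound 2 gives > 25000 nM, which is a limit of this assay and not a number. Compound 3 `NC(=O)c1c(NC(=O)Nc2ccc(Cl)cc2)sc2c1CCN(CC1CCCC1)C2` keeps the shared core and differs from compound 2 in one place, where cyclopentylmethyl stands in place of tert-butoxycarbonyl on an amine nitrogen in a ring: cyclopentylmethyl in place of tert-butoxycarbonyl on an amine nitrogen in a ring.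

Among the compounds with values here, only one measured step bears on this change, and it lies at the same nitrogen: an at least 8.8-fold higher number from compound 1 to compound 2 (0.94 log units; beyond the scatter). Within the data shown here, that step is beyond the scatter, and it is the only measured example of tert-butoxycarbonyl set against another group there. Compound 3 also lacks tert-butoxycarbonyl, so a step of similar size toward lower numbers is expected in this assay, resting on compound 1 with 2830 nM. One example is thin support, and cyclopentylmethyl is not oxan-4-yl, so the expectation stays wide. The estimated change is an at least 8.3-fold lower number from compound 2 to compound 3 (0.92 log units; beyond the scatter). For compound 3 the estimated value is 3000 nM, with an expected range from 800 nM to 12000 nM.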

Compound 3, half-maximal effective concentration: 1830 nM
Estimate against measurement, compound 3: 1.6-fold (0.21 log units) above; measured number inside the range.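

Setting cyclopentylmethyl in place of tert-butoxycarbonyl on the amine nitrogen in a ring gives an at least 13-fold lower number from compound 2 to compound 3 (1.13 log units; beyond the scatter) in this assay, which means that tert-butoxycarbonyl now stands apart from two different groups at this nitrogen rather than from oxan-4-yl alone. The two groups that replace it, oxan-4-yl and cyclopentylmethyl, cannot be told apart in this assay, with a 1.5-fold lower number from compound 1 to compound 3 (0.19 log units; within the scatter); at this nitrogen, then, the read-out does not separate a group that carries a ring oxygen from one whose ring holds carbon only. Compound 2 remains a limit of the assay and not a number, so the step from it fixes only a minimum size: the limit of > 25000 nM in this assay, at which 1 of the 3 values shown sits.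

Compound 2 is the only one shown with a carbonyl attached to this nitrogen, and it stays open whether a small acetyl group would also lie at the limit or whether the effect belongs to tert-butoxycarbonyl alone. Going by these compounds, it is equally open how far the tolerance seen here extends, whether to a benzyl group, a longer chain, a carboxylic acid or a free ring amine with only hydrogen on the nitrogen.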